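Sulfonyl hydrazides against indoleamine 2,3-dioxygenase 1: a cyano variant

The source may hold more compounds than are shown below. What is called first, only, known or untested is meant among the compounds shown, and "the series" means these compounds.

Working notes on a small set of aryl sulfonyl hydrazides bearing a bromophenyl hydrazine. Compound 1 `CC(=O)Nc1ccc(S(=O)(=O)NNc2cccc(Br)c2)cc1` and compound 2 `O=S(=O)(NNc1ccc(Br)cc1)c1ccccc1` have been measured in an assay for inhibition of Indoleamine 2,3-dioxygenase 1 (Homo sapiens), read by spectrophotometry, with stated times of 1 h and 4 h; a lower number here means a stronger inhibitor, a higher number a weaker inhibitor. Compound 1 gives 255 nM. Compound 2 gives 172 nM, a number that lies within the usual scatter of the number for compound 1, so the two cannot be told apart on these data.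

The next step goes from compound 2 to compound 3 `N#Cc1ccc(S(=O)(=O)NNc2ccc(Br)cc2)cc1`. The change is cyano in place of hydrogen on an aromatic carbon, on a six-membered aromatic ring of carbon only, para to a large group. No measured pair in this set shows what such a change does in this assay; compound 1, which carries a different group in a comparable position, sits within the scatter of compound 2, so the shown numbers give no firm direction.

Compound 3 is therefore expected to come out close to compound 2, with the step of a 1.4-fold lower number from compound 2 to compound 3 (0.16 log units; within the scatter) estimated as small, perhaps a modest gain. The estimate for compound 3 is 120 nM, within a range of 50 nM to 350 nM.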

Compound 3, half-maximal inhibitory concentration: 176 nM
Estimate against measurement, compound 3: 1.5-fold (0.17 log units) below, and the stated range covers the measured number.
By their numbers in this assay, from the lowest: compounds 2, 3 and 1 (each within the scatter of the next).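

In this assay, for the compounds shown here, the change of cyano in place of hydrogen on an aromatic carbon, para to a large group, gives a 1.0-fold higher number from compound 2 to compound 3 (0.01 log units; within the scatter) and so provides the first direct reading at this position. The step lies within the scatter, so the assay resolves no difference between the hydrogen of compound 2 and the cyano group of compound 3. On these data the position carries a cyano group, with its 2 heavy atoms and triple bond, without a readable loss, and no available measurement explains the size of this step.

The compounds shown leave open whether an amine, a carboxylic acid or a longer chain at this same position would also stay within the scatter of compound 2, or whether one of them would give a clear step in either direction. Compound 1 differs from compound 2 in more than one place, so the contribution of its acetylated amine at a comparable position cannot be separated from the other difference and remains unresolved as a single step.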